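From Chloro to Methoxy: Expected Solubility of Compound 4

The source may report more compounds than this note shows. Statements on the series, on what has been measured and on what is new or still open speak of the compounds shown alone.

Three compounds built on one shared core were tested in a physicochemical assay for solubility, at pH 7.4; a lower number here means a less soluble compound, a higher number a more soluble compound. Compound 1 `CCCCNc1nc(NCc2ccccc2)c2ccccc2n1` gives <= 10000 nM, a limit of the assay rather than a number. Compound 2 `c1ccc(CNc2nc(Nc3ccccc3)c3ccccc3n2)cc1` gives <= 5000 nM, also a limit. Compound 3 `CC(C)Nc1nc(NCc2ccco2)c2cccc(Cl)c2n1` gives <= 5000 nM, again only a limit. Compound 3 thus sits at the limit of <= 5000 nM in this assay, at which 2 of the 3 values shown sit, while the remaining value sits at the limit of <= 10000 nM in this assay, at which 1 of the 3 values shown sits, so none of the three carries a true number. Compound 4 `COc1cccc2c(NCc3ccco3)nc(NC(C)C)nc12` differs from compound 3 by methoxy in place of chloro on an aromatic carbon. No measured step joins any two of these compounds, so the size of this change cannot be read from them; it is expected to stay within the usual scatter, and the result may again be reported as a limit. Compound 4 is therefore estimated at 4000 nM, between 1000 nM and 15000 nM, which means an expected step that the limit leaves unreadable from compound 3 to compound 4.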

Compound 4, solubility: <= 20000 nM
Compound 4: no number, only a limit; the forecaster's own chance of this, stated with the estimate: 60%; the middle value lies beyond the limit too.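

Among these compounds, compound 3 and compound 4 are both reported only as limits in this assay, so no step between them can be read. From the compounds shown here alone, whether methoxy in place of chloro on an aromatic carbon changes solubility, and by how much, stays open.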